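Removing the Methyl from Compound 1

A few compounds are considered here, and "the series" means these few. Any claim that something is new, unique, unknown or untested is made for them only; others in the source may bear on it.

Compound 1 `Cc1ccc(OCC2CC2)cc1-c1cccc(COc2ccc(OCC(=O)O)c(F)c2)c1` is the reference point in a functional assay on CHO cells for agonist activity at Free fatty acid receptor 1 (Homo sapiens), read by FLIPR and calcium flux (on this read-out lower numbers stand for an effect already at smaller amounts and higher numbers for an effect only at larger amounts of compound), where compound 1 gives 340 nM, the lowest of the three numbers recorded. Compound 3 `Cc1ccc(OCCC2CCCCC2)cc1-c1cccc(COc2ccc(OCC(=O)O)c(F)c2)c1` gives 520 nM, and a 1.5-fold higher number from compound 1 to compound 3 (0.18 log units; within the scatter). Compound 2 `Cc1ccc(OCC2CCC2)cc1-c1cccc(COc2ccc(OCC(=O)O)c(F)c2)c1` gives 1530 nM, and a 4.5-fold higher number from compound 1 to compound 2 (0.65 log units; beyond the scatter). Compound 4 `O=C(O)COc1ccc(OCc2cccc(-c3cccc(OCC4CC4)c3)c2)cc1F` differs from compound 1 by hydrogen in place of methyl on an aromatic carbon. Going by the values given here, none of the measured steps touches this part of the molecule: each of them, including a 2.9-fold lower number from compound 2 to compound 3 (0.47 log units; beyond the scatter), exchanges the ring on the saturated chain carbon bound to an oxygen on an aromatic ring, so no step bears on the loss of the methyl. Lacking such a comparison, the expected step is a 2.1-fold higher number from compound 1 to compound 4 (0.31 log units; beyond the scatter), a cautious guess that stays near the scatter. Compound 4 is therefore estimated at about 700 nM, with a range from 200 nM to 2500 nM.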

Compound 4, half-maximal effective concentration: 670 nM
The estimate for compound 4 lay 1.0-fold (0.02 log units) above the measured number; low and high end bracket the measured number.
By their numbers in this assay, from the lowest: compounds 1, 3 and 4 (each within the scatter of the next); then compound 2.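

In this assay, the single methyl on this aromatic carbon, ortho to a large group and para to a cyclopropylmethoxy group, gives way to hydrogen with a 2.0-fold higher number from compound 1 to compound 4 (0.29 log units; within the scatter). This position can therefore lose that carbon without a step beyond the scatter, at least with the cyclopropylmethoxy group in place. No measurement shown here explains this result. Still open, as far as these compounds go, is what a methoxy group or a chlorine atom on this carbon would give, and whether losing the methyl reads the same with the cyclobutylmethoxy group of compound 2.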